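Fluorine on the anilino ring of a dimethoxy core

The compounds below may be only part of what the source reports. "The series", "measured", "known", "first", "only" and "open" are said of these compounds alone.

Compound 1 `COc1cc2nc(N3CCC4CCC(C3)N4Cc3ccccc3)nc(Nc3ccc(S(C)(=O)=O)cc3F)c2cc1OC`: > 10000 nM
Compound 2 `COc1cc2nc(N3CCC4CCC(C3)N4C(=O)OC(C)(C)C)nc(Nc3ccc(S(C)(=O)=O)cc3)c2cc1OC`: > 10000 nM

In a functional assay on HEK293 cells for agonist activity at Glucose-dependent insulinotropic receptor (Homo sapiens), read by cAMP accumulation, with a stated time of 60 min (a higher number here means that more compound is needed for the effect, a lower number that less compound is needed), compound 1 reaches only the assay limit, > 10000 nM. Compound 2 likewise gives no number in this assay but only a limit, > 10000 nM. Compound 2 therefore stands where every value shown stands, at the limit of > 10000 nM in this assay, at which 2 of the 2 values shown sit, so no ordering among the measured compounds can be read from these data.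

Compound 3 `COc1cc2nc(N3CCC4CCC(C3)N4C(=O)OC(C)(C)C)nc(Nc3ccc(S(C)(=O)=O)cc3F)c2cc1OC` differs from compound 2 in one place: fluoro in place of hydrogen on an aromatic carbon. Within the data shown here, no step between measured compounds is known, and compound 1 carries the same fluoro group while also sitting at the limit. Compound 3 is therefore expected to remain at or beyond the limit, with an estimated step that the limit leaves unreadable from compound 2 to compound 3 that means no change beyond the usual scatter. The estimate for compound 3 in this assay is 15000 nM, ranging from 5000 nM to 50000 nM.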

Compound 3, half-maximal effective concentration: 1000 nM
Estimate against measurement, compound 3: 15-fold (1.18 log units) above, outside the stated range (below it).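

In this assay, fluoro in place of hydrogen on this aromatic carbon, ortho to a large group and meta to a methylsulfonyl group, gives an at least 10-fold lower number from compound 2 to compound 3 (1.00 log units; beyond the scatter), the first change shown that brings a compound off the limit. The fluoro group does not do this on its own: with fluoro present in both compounds, tert-butoxycarbonyl in place of benzyl on the amine nitrogen in a ring gives an at least 10-fold lower number from compound 1 to compound 3 (1.00 log units; beyond the scatter). Both steps are therefore minimum sizes, each starting from a compound held at a limit: the limit of > 10000 nM in this assay, at which 2 of the 3 values shown sit.

On these data alone, the true size of either step stays open. So does whether a chloro or methoxy group on this aromatic carbon would serve as fluoro does, and whether a urea or an acetyl group could replace tert-butoxycarbonyl on that nitrogen.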